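A few compounds are considered here, and "the series" means these few. Any claim that something is new, unique, unknown or untested is made for them only; others in the source may bear on it.

Of the compounds shown here, two have numbers so far. Compound 1 `O=C1C[C@H](NC(=O)[C@@H]2CNC[C@@H]3CCCC[C@H](NC(=O)c4nccc5ccccc45)C(=O)N32)C(O)O1` gives 595 nM in an assay on isolated protein for inhibition of Caspase-8 (Homo sapiens); on this read-out higher numbers stand for weaker inhibition and lower numbers for stronger inhibition. Compound 2 `O=C1C[C@H](NC(=O)[C@@H]2COC[C@@H]3CCCC[C@H](NC(=O)c4cc5ccccc5s4)C(=O)N32)C(O)O1` gives 429 nM in this assay, the lower of the two numbers, though its gap to compound 1 lies within the scatter. Compound 3 `O=C1C[C@H](NC(=O)[C@@H]2COC[C@@H]3CCCC[C@H](NC(=O)c4nccc5ccccc45)C(=O)N32)C(O)O1` differs from compound 2 in one place: isoquinolin-1-yl in place of 1-benzothiophen-2-yl on a carbonyl carbon. Going by the values given here, no measured pair shows this change alone; because compound 1 already carries the isoquinolinyl group and gives 595 nM, no step in this assay beyond the scatter is expected. Compound 3 is therefore expected to give 500 nM, between 200 nM and 1500 nM. This amounts to an expected 1.2-fold higher number from compound 2 to compound 3 (0.07 log units; within the scatter).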

Compound 3, half-maximal inhibitory concentration: 264 nM
Compound 3: the middle estimate sits 1.9-fold (0.28 log units) above what was measured, and the stated range covers the measured number.
By their numbers in this assay, from the lowest: compounds 3, 2 and 1 (each within the scatter of the next, the first and the last beyond it).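

Going by these compounds alone, this is the first direct comparison of the two groups on a carbonyl carbon whose other neighbour is an amide-type nitrogen. In this assay, replacing 1-benzothiophen-2-yl with isoquinolin-1-yl gives a 1.6-fold lower number from compound 2 to compound 3 (0.21 log units; within the scatter), so the two fused aromatic groups cannot be told apart here. Nothing available explains this similarity.

From the compounds shown here alone, it remains open whether a single phenyl ring, or an isoquinolin-1-yl group carrying an amine or a carboxylic acid, would shift the number beyond the scatter. Going by these compounds, the same change on the core of compound 1 also remains open.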